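The source may report more compounds than this note shows. Statements on the series, on what has been measured and on what is new or still open speak of the compounds shown alone.

Working notes on the series, read in an ADME assay on RAW264.7 cells (Mus musculus) for cytotoxicity, read by MTT assay, with a stated time of 24 h, in the presence of a further agent that is not named here; a higher number here means a weaker inhibitor, a lower number a stronger inhibitor. Compound 1 (`COc1ccc(C(O)C2OC(=O)c3c(OC)cc(OC)cc32)cc1`) gives > 40000 nM, which is a limit and not a number. Compound 2 (`COCCCOc1ccc(C(O)C2OC(=O)c3c(OC)cc(OC)cc32)cc1`) gives > 40000 nM, again a limit. Compound 3 (`COc1cc(OC)c2c(c1)C(C(O)c1ccc(OCc3ccc(OC(F)(F)F)cc3)cc1)OC2=O`) gives > 40000 nM, also a limit, so compound 3 has no number of its own. It stands at the limit of > 40000 nM in this assay, at which 3 of the 3 values shown sit.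

Compound 4 (`COc1cc(OC)c2c(c1)C(C(O)c1ccc(OCc3ccc(OC(F)F)cc3)cc1)OC2=O`) departs from compound 3 by one change: hydrogen in place of fluoro on a saturated chain carbon bound to two fluorine atoms and an oxygen on an aromatic ring. In words, hydrogen replaces fluoro, and 4-(trifluoromethoxy)phenyl becomes 4-(difluoromethoxy)phenyl.

Going by the values given here, two measured steps touch the same side chain: a step that the two limits leave unreadable from compound 1 to compound 3 and a step that the two limits leave unreadable from compound 2 to compound 3. The third, a step that the two limits leave unreadable from compound 1 to compound 2, is no more informative. None of them gives a size, and none concerns this exact change. In this assay no step beyond the scatter is therefore expected, and no direction can be given. The expected step, a step that the limit leaves unreadable from compound 3 to compound 4, is an estimate resting on that limit. For compound 4 the estimate is 50000 nM, with an expected range of 25000 nM to 100000 nM, and a report as a limit is the likely outcome.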

Compound 4, half-maximal inhibitory concentration: > 40000 nM
Compound 4 ended at the assay's limit; the forecaster's own chance of this, stated with the estimate: 85%; the middle value lies beyond the limit too.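

In this assay compound 4 gives > 40000 nM, which is a limit. Going by these compounds alone, no step to compound 4 from compound 1, compound 2 or compound 3 can be read. The compounds shown leave open whether any side chain on the shared core gives a measurable value in this assay.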